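The source may report more compounds than this note shows. Statements on the series, on what has been measured and on what is new or still open speak of the compounds shown alone.

Compound 1 `COc1nc(C2CCOCC2)ccc1[C@@H](c1ccccc1)[C@@](O)(CCN(C)C)c1cccc2ccccc12`, compound 2 `COc1nc(-c2ccc(Cl)cc2)ccc1[C@@H](c1ccccc1)[C@@](O)(CCN(C)C)c1cccc2ccccc12` and compound 3 `COc1ccc(-c2ccc([C@@H](c3ccccc3)[C@@](O)(CCN(C)C)c3cccc4ccccc34)c(OC)n2)cc1` share one core and differ only in the group on the aromatic carbon of the pyridine-like ring. Among the measured compounds shown here, in a toxicity assay on HeLa cells (Homo sapiens) for cytotoxicity (on this read-out higher numbers stand for lower toxicity in this test and lower numbers for higher toxicity in this test), compound 1 gives 22.5 ug/mL, the only plain number among the three values shown. For compound 2 this assay reports only a limit, > 64 ug/mL. For compound 3 it likewise reports only a limit, > 64 ug/mL. So two of the three results sit at the limit of > 64 ug/mL in this assay, at which 2 of the 3 values shown sit. The readable steps are an at least 2.8-fold higher number from compound 1 to compound 2 (0.45 log units; beyond the scatter) and an at least 2.8-fold higher number from compound 1 to compound 3 (0.45 log units; beyond the scatter); between compound 2 and compound 3 the two limits show nothing of the size of the step. Compound 4 `COc1nc(C2CCCCC2)ccc1[C@@H](c1ccccc1)[C@@](O)(CCN(C)C)c1cccc2ccccc12` is not yet measured; it differs from compound 1 in this way: cyclohexyl in place of oxan-4-yl on an aromatic carbon. Both measured steps placed an aromatic ring there, and neither says directly what a carbon-only non-aromatic ring does in that place. Compound 4 is therefore expected to sit close to compound 1 in this assay, with a step of a 1.3-fold higher number from compound 1 to compound 4 (0.12 log units; within the scatter) that may not pass the scatter. The estimate for compound 4 is 30 ug/mL, spanning 12 ug/mL to 70 ug/mL.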

Compound 4, half-maximal cytotoxic concentration: 57.7 ug/mL
Estimate against measurement, compound 4: 1.9-fold (0.28 log units) below; the measured number falls inside the stated range.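

Exchanging oxan-4-yl for cyclohexyl in this assay gives a 2.6-fold higher number from compound 1 to compound 4 (0.41 log units; beyond the scatter). This shows that an aromatic ring is not needed at this place, next to the ring nitrogen, for a number higher than that of compound 1: a non-aromatic six-membered ring of carbon only also gives one, and the change takes away just the ring oxygen. Against the two aromatic groups the steps are an at least 1.1-fold lower number from compound 3 to compound 4 (0.04 log units; that floor lies within the scatter) and an at least 1.1-fold lower number from compound 2 to compound 4 (0.04 log units; that floor lies within the scatter), floors that fix no order, since compound 2 and compound 3 stand only at a limit of the assay: the limit of > 64 ug/mL in this assay, at which 2 of the 4 values shown sit.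

Going by these compounds, how far compound 2 and compound 3 lie past that limit stays open. So does what a piperidin-4-yl ring, with nitrogen in place of the ring oxygen, or an open hexyl chain would give at this place.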